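A few compounds are considered here, and "the series" means these few. Any claim that something is new, unique, unknown or untested is made for them only; others in the source may bear on it.

Compound 1 `N#CC1=C(N)Oc2c(c3nc4ccccc4nc3c3ccccc23)C12C(=O)N(Cc1cnnn1-c1ccc(Br)cc1)c1ccccc12`: > 50000 nM
Compound 2 `N#CC1=C(N)Oc2c(c3nc4ccccc4nc3c3ccccc23)C12C(=O)N(Cc1cnnn1-c1ccc([N+](=O)[O-])cc1)c1ccccc12`: > 50000 nM
Compound 3 `N#CC1=C(N)Oc2c(c3nc4ccccc4nc3c3ccccc23)C12C(=O)N(Cc1cnnn1-c1ccc(N)cc1)c1ccccc12`: 45200 nM

These three compounds were tested in a functional assay on HCT-116 cells (Homo sapiens) for antiproliferative activity, read by MTT assay, with a stated time of 48 h; on this read-out higher numbers stand for weaker inhibition and lower numbers for stronger inhibition. Compound 1 gives only a limit there, > 50000 nM, so its true value is not known as a number. Compound 2 likewise gives only a limit, > 50000 nM. Both sit at the limit of > 50000 nM in this assay, at which 2 of the 3 values shown sit. Within the data shown here, compound 3 is the only one to give a number, 45200 nM. The steps among them are small or unreadable: a step that the two limits leave unreadable from compound 1 to compound 2, an at least 1.1-fold lower number from compound 1 to compound 3 (0.04 log units; that floor lies within the scatter) and an at least 1.1-fold lower number from compound 2 to compound 3 (0.04 log units; that floor lies within the scatter). Compound 1 thus stands at the limit of the shown numbers, without a measurable difference from the others.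

Compound 4 `Cc1ccc(-n2nncc2CN2C(=O)C3(C(C#N)=C(N)Oc4c3c3nc5ccccc5nc3c3ccccc43)c3ccccc32)cc1Cl` differs from compound 1 in one place: 3-chloro-4-methylphenyl in place of 4-bromophenyl on an aromatic nitrogen. Among the measured compounds shown here, all the measured steps change the group on the same aromatic nitrogen, and none of them produced a readable shift beyond the scatter. The change to compound 4 is therefore expected to give no step beyond the scatter in this assay, a number no higher from compound 1 to compound 4 (the limit leaves the size open). Compound 4 is estimated at 50000 nM, within a range from 25000 nM to 150000 nM, and is likely to be reported again only as a limit.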

Compound 4, half-maximal inhibitory concentration: > 50000 nM
Compound 4 was reported as a limit; the forecaster's own chance of this, stated with the estimate: 70%; the middle value sits exactly at the limit.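

Compound 4 widens the range tried on this aromatic nitrogen from a phenyl ring with one group to 3-chloro-4-methylphenyl, a ring carrying both a chlorine and a methyl, yet its result in this assay is still only a limit and not a number: the limit of > 50000 nM in this assay, at which 3 of the 4 values shown sit. The steps to compound 4 from compound 1 and from compound 2 cannot be read, as both ends of each step are limits. Among these compounds, the one comparison that can be read is an at least 1.1-fold higher number from compound 3 to compound 4 (0.04 log units; that floor lies within the scatter), so these results do not set compound 3 apart from compound 4, and no change at this position has yet produced a shift beyond the scatter.

The compounds shown leave open whether any group on this nitrogen could bring the number clearly down, for example a carboxylic acid on the phenyl ring or a butyl chain in place of the ring. They also leave open whether a change elsewhere on the shared core, which is the same in all four compounds, would matter more than a change at this position.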